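This account rests on a few compounds, and the source may have more. Where it says the series, first, only, none or still open, it means among the compounds named here.

Working notes on the series. In a functional assay on MCF7 cells (Homo sapiens) for inhibition, read by sulforhodamine B assay, with a stated time of 48 h, tested at 10 uM (on this read-out lower numbers stand for less inhibition of growth and higher numbers for more inhibition of growth at the one concentration tested), compound 1 `CC(=O)c1ccc(Nc2ccnc(SCC(=O)c3ccc(Br)cc3)n2)cc1` gives 18%, compound 3 `CC(=O)c1ccc(Nc2ccnc(SCC(=O)c3ccc(Cl)cc3)n2)cc1` gives 19%, and compound 2 `CC(=O)c1cccc(Nc2ccnc(SCC(=O)c3ccc(-c4ccccc4)cc3)n2)c1` gives 12%; all three numbers lie within the scatter of one another, so compound 2 stands with the others at the low end of the read-out rather than apart from them. Going by the values given here, the one measured step at the position of interest, a number 1 percentage points higher from compound 1 to compound 3 (within the scatter), is a halogen swap that leaves this assay unchanged. Compound 4 `COc1ccc(C(=O)CSc2nccc(Nc3cccc(C(C)=O)c3)n2)cc1` differs from compound 2 by methoxy in place of phenyl on an aromatic carbon. Among the compounds with values here, no measured step covers a phenyl to methoxy change, and the halogen step gives no sign that this position moves the read-out, so compound 4 is expected at 14% (range 4% to 26%), with a number 2 percentage points higher from compound 2 to compound 4 (within the scatter) expected to stay within the scatter.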

Compound 4, percent growth inhibition at one concentration: 11%
Beside the measured number, compound 4's estimate is 3 percentage points above it; the range from low to high includes it.
By their numbers in this assay, from the lowest: compounds 4, 2, 1 and 3 (each within the scatter of the next).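

In this assay, methoxy in place of phenyl gives a number 1 percentage points lower from compound 2 to compound 4 (within the scatter). The halogen step exchanged one small substituent for another, whereas this step removes a six-membered aromatic ring of carbon only and brings in a hydrogen-bond acceptor, and the read-out still does not separate the pair. Nothing available explains why this larger change leaves the number within the scatter.

Going by these compounds, whether an amine or a carboxylic acid on this aromatic carbon would move the read-out remains open. Also open, on these data alone, is whether methoxy in place of phenyl would behave the same way on the core of compound 1.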